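The compounds below may be only part of what the source reports. "The series", "measured", "known", "first", "only" and "open" are said of these compounds alone.

In a physicochemical assay for solubility (on this read-out higher numbers stand for higher solubility and lower numbers for lower solubility), compound 3 `CNC(=O)c1cc(C(=O)N[C@H]2[C@@H]3COC[C@@H]32)cc2c1OC[C@H]2c1ccccn1` gives >= 158 ug/mL, which is a limit of the assay and not a number. Compound 1 `CNC(=O)c1cc(C(=O)N[C@H]2[C@@H]3COC[C@@H]32)cc2c1OC[C@H]2c1cccc2[nH]ccc12` gives >= 171 ug/mL, also a limit. Compound 2 `CNC(=O)c1cc(C(=O)N[C@H]2[C@@H]3COC[C@@H]32)cc2c1OC[C@H]2c1ccncc1` gives >= 184 ug/mL, again a limit. So all three measured compounds stand at limits, and none has an exact value.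

Compound 4 `CNC(=O)c1cc(C(=O)N[C@H]2[C@@H]3COC[C@@H]32)cc2c1OC[C@H]2C1CCOCC1` has not yet been measured. It has oxan-4-yl in place of pyridin-2-yl on a saturated ring carbon.

The measured steps that bear on this change sit on that same carbon. They are a step that the two limits leave unreadable from compound 1 to compound 2, a step that the two limits leave unreadable from compound 1 to compound 3 and a step that the two limits leave unreadable from compound 2 to compound 3. None has a readable size, so they offer no measured effect to carry over. The indole-bearing and pyridine-bearing compounds all gave limits, so compound 4 is expected to give a limit as well, with no step beyond the scatter in either direction.

The estimated step is a step that the limit leaves unreadable from compound 3 to compound 4. For compound 4 the expected value is 170 ug/mL, with an estimated range from 110 ug/mL to 230 ug/mL.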

Compound 4, solubility: >= 177 ug/mL
Compound 4: no number, only a limit; the forecaster's own chance of this, stated with the estimate: 80%; at least 1.0-fold (0.01 log units) between middle value and limit.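

Compound 4 also stands at a limit in this assay, so its steps from compound 1, compound 2 and compound 3 cannot be read. The compounds shown leave open where the true read-out of any of these four compounds lies, and whether swapping the group on that saturated ring carbon changes it at all.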